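This account rests on a few compounds, and the source may have more. Where it says the series, first, only, none or still open, it means among the compounds named here.

Measured compounds:
Compound 1, `CCC(C1CC1)n1c(=O)c(C)nc2c(-c3cc(Cl)c(OC)cc3OC)ccnc21`: 3.4 nM
Compound 2, `CCCC(C1CC1)n1c(=O)c(C)nc2c(-c3ccc(Cl)cc3Cl)ccnc21`: 4.3 nM
Compound 3, `CC[C@H](C1CC1)n1c(=O)c(C)nc2c(-c3cc(C)c(OC)nc3C)ccnc21`: 15 nM

Of the compounds shown here, three on a shared core have been measured in a functional assay for antagonist activity at corticotropin-releasing factor receptor 1 (Rattus norvegicus); a higher number here means a weaker inhibitor, a lower number a stronger inhibitor. Compound 2 gives 4.3 nM there, the second highest of the three numbers; its nearest neighbour is compound 1 at 3.4 nM, a gap that lies within the scatter, so no order can be drawn between them. Furthest from compound 2 stands compound 3 with 15 nM, and that gap lies beyond the scatter.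

Compound 4, `Cc1nc2c(-c3ccc(Cl)cc3Cl)ccnc2n(CC(C)C)c1=O`, has not yet been measured. It differs from compound 2 in one place: isobutyl in place of 1-cyclopropylbutyl on an aromatic nitrogen. Among the compounds with values here, no pair of measured compounds shows this change alone, so its effect cannot be read from the data at hand. Going by these compounds, the three measured compounds all carry a branched group with a three-membered ring on that nitrogen, and all give low numbers; the smaller, ring-free isobutyl is untested here. The step from compound 2 to compound 4 is expected to run toward a higher number, of a size somewhat beyond the scatter, a 3.5-fold higher number from compound 2 to compound 4 (0.54 log units; beyond the scatter). Compound 4 is accordingly estimated at 15 nM in this assay, with a range from 4 nM to 60 nM.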

Compound 4, half-maximal inhibitory concentration: 3500 nM
Compound 4: middle estimate off by 230-fold (2.37 log units), on the low side; measured number above the stated range.
By their numbers in this assay, from the lowest: compounds 1 and 2 (each within the scatter of the next); then compound 3; then compound 4.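

In this assay, isobutyl in place of 1-cyclopropylbutyl on the aromatic nitrogen gives an 810-fold higher number from compound 2 to compound 4 (2.91 log units; beyond the scatter) and is the only step shown that isolates this position. The three earlier compounds all carry a group with a three-membered ring here, so they could not show how strongly the number depends on this substituent. The change removes that ring and also shortens the group from 7 heavy atoms to 4, and nothing at hand accounts for the size of the step.

The compounds shown leave open whether the ring or the size of the group carries this step: what cyclopropylmethyl or the ring-free 1-propylbutyl would give on this nitrogen remains unknown. Also open, going by these compounds, is whether a step of this size would recur with the other aromatic groups of compound 1 and compound 3.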